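Methyl on a Phenol Oxygen in Two Cinnamate Ester Pairs

This account rests on a few compounds, and the source may have more. Where it says the series, first, only, none or still open, it means among the compounds named here.

Compound 1 `O=C(/C=C/c1ccc(O)c(O)c1)OCc1c(-c2ccccc2)no[n+]1[O-]`: in a functional assay on NCI-H1299 cells (Homo sapiens) for cytotoxicity, read by resazurin assay, with a stated time of 72 h (a higher number here means a weaker inhibitor, a lower number a stronger inhibitor), compound 1 reaches only the limit > 50000 nM.
Compound 2 `COc1cc(/C=C/C(=O)OCc2c(-c3ccccc3)no[n+]2[O-])ccc1O`: in this assay compound 2 gives 12900 nM.
Compound 3 `O=C(/C=C/c1ccc(OCCCCCCO[N+](=O)[O-])c(O)c1)OCCCCCCO[N+](=O)[O-]`: in this assay compound 3 reaches only the limit > 50000 nM.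

The change from compound 1 to compound 2 is methyl in place of hydrogen on an oxygen on an aromatic ring, and it brings an at least 3.8-fold lower number from compound 1 to compound 2 (0.58 log units; beyond the scatter). Its size is only a lower bound, because compound 1 sits at the limit of > 50000 nM in this assay, at which 2 of the 3 values shown sit. The difference between the cores of compound 1 and compound 3 is not broken down here.

Compound 4 `COc1cc(/C=C/C(=O)OCCCCCCO[N+](=O)[O-])ccc1OCCCCCCO[N+](=O)[O-]` differs from compound 3 by methyl in place of hydrogen on an oxygen on an aromatic ring, the same change. Compound 4 is expected to show an at least 3.3-fold lower number from compound 3 to compound 4 (0.52 log units; beyond the scatter), resting on an at least 3.8-fold lower number from compound 1 to compound 2 (0.58 log units; beyond the scatter), which is itself only a bound. Compound 4 is therefore estimated at about 15000 nM in this assay, within 4000 nM to 50000 nM.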

Compound 4, half-maximal inhibitory concentration: > 50000 nM
Compound 4: a limit, no number; the forecaster's own chance of this, stated with the estimate: 40%; middle value at least 3.3-fold (0.52 log units) from the limit.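

The step from compound 3 to compound 4 cannot be read, because both compounds sit at the same limit: the limit of > 50000 nM in this assay, at which 3 of the 4 values shown sit.

From the compounds shown here alone, whether hydroxy to methoxy changes the number at all in this pair, as it does between compound 1 and compound 2, stays open.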